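The source may report more compounds than this note shows. Statements on the series, on what has been measured and on what is new or still open speak of the compounds shown alone.

Measured so far in a functional assay on HCT-116 cells (Homo sapiens) for cytotoxicity, read by MTT assay, with a stated time of 48 h; a higher number here means a weaker inhibitor, a lower number a stronger inhibitor:
Compound 1 `CCN(CC)c1ccc2cc(C(=O)c3ccc(N4CCN(C(=O)CN5CCN(S(=O)(=O)C6CC6)CC5)CC4)cc3)oc2c1` gives > 40000 nM, a limit of the assay.
Compound 2 `CCN(CC)c1ccc2cc(C(=O)c3ccc(N4CCN(C(=O)CN5CCN(S(=O)(=O)c6ccc(C#N)cc6)CC5)CC4)cc3)oc2c1` gives 36400 nM.
Compound 3 `CCN(CC)c1ccc2cc(C(=O)c3ccc(N4CCN(C(=O)CN5CCN(Cc6ccc(C(F)(F)F)cc6)CC5)CC4)cc3)oc2c1` gives > 40000 nM, a limit of the assay.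

Compound 3 therefore stands at the limit of > 40000 nM in this assay, at which 2 of the 3 values shown sit; only compound 2 gives a number at all. Compound 4 `CCN(CC)c1ccc2cc(C(=O)c3ccc(N4CCN(C(=O)CN5CCN(Cc6ccc(C#N)cc6)CC5)CC4)cc3)oc2c1` differs from compound 3 by cyano in place of trifluoromethyl on an aromatic carbon. Among the measured compounds shown here, no measured step changes a group on a benzyl in this way; the nearest are an at least 1.0-fold lower number from compound 1 to compound 2 (0.04 log units; that floor lies within the scatter) and an at least 1.0-fold higher number from compound 2 to compound 3 (0.04 log units; that floor lies within the scatter), both sitting at their floors and within the scatter, while a step that the two limits leave unreadable from compound 1 to compound 3. Nothing here points to a move beyond the scatter in this assay. Compound 4 is therefore expected to stay at or near the limit, the step of a number no higher from compound 3 to compound 4 (the limit leaves the size open) being estimated as none beyond the scatter. Compound 4 is expected at 40000 nM, between 20000 nM and 80000 nM.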

Compound 4, half-maximal inhibitory concentration: > 40000 nM
Compound 4: only a limit was reported (the forecaster's own chance of this, stated with the estimate: 70%); the middle value lies on the limit itself.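

In this assay, a cyano on the benzyl ring leaves the compound where trifluoromethyl left it, at a limit of the assay: the limit of > 40000 nM in this assay, at which 3 of the 4 values shown sit. The steps to compound 4 from compound 1 and from compound 3 cannot be read, since both ends are limits. Exchanging (4-cyanophenyl)sulfonyl for 4-cyanobenzyl gives an at least 1.0-fold higher number from compound 2 to compound 4 (0.04 log units; that floor lies within the scatter), so the cyano-bearing pair shows no separation beyond the scatter.

As far as these compounds go, whether an amine or a carboxylic acid on the benzyl ring, or a longer chain in place of the benzyl, would bring a readable value stays open. From the compounds shown here alone, how far compound 3 and compound 4 lie past the limit also stays open.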